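The source may report more compounds than this note shows. Statements on the series, on what has been measured and on what is new or still open speak of the compounds shown alone.

Going by the values given here, in a physicochemical assay for lipophilicity, measured as octanol-water partition, with a stated time of 72 h (on this read-out higher numbers stand for higher lipophilicity and lower numbers for lower lipophilicity), compound 2 `CCCCNC(=O)NO` gives 0.32, the higher of the two numbers so far, and compound 1 `CCNC(=O)NO` gives -0.76. Compound 3 `CCCNC(=O)NO` has not been measured. It differs from compound 2 by hydrogen in place of methyl on a saturated chain carbon, three bonds along the chain from an amide-type nitrogen. Among the compounds with values here, the one measured step that bears on this is a number 1.08 log units higher from compound 1 to compound 2 (beyond the scatter), with ethyl in place of hydrogen. The new change undoes part of that one, so a smaller fall in this assay is expected, estimated as a number 0.54 log units lower from compound 2 to compound 3 (beyond the scatter). The estimate for compound 3 is -0.22, with an expected range of -0.5 to 0.05.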

Compound 3, partition coefficient: 0.22
Estimate against measurement, compound 3: 0.44 log units below, and the stated range ends below it.
By their numbers in this assay, from the lowest: compound 1; then compounds 3 and 2 (each within the scatter of the next).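

In this assay, hydrogen in place of methyl at this place, three bonds along the chain from an amide-type nitrogen, gives a number 0.10 log units lower from compound 2 to compound 3 (within the scatter) and so leaves compound 2 and compound 3 indistinguishable. Methyl in place of hydrogen two bonds along the chain gives a number 0.98 log units higher from compound 1 to compound 3 (beyond the scatter) and thus accounts for most of the earlier rise. No measurement offered here gives a reason for this result. Still open, going by these compounds, is how this assay would read a longer chain such as pentyl, or a chain carrying an amine or a carboxylic acid.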